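The source may report more compounds than this note shows. Statements on the series, on what has been measured and on what is new or still open speak of the compounds shown alone.

Of the compounds shown here, three built on one shared core have been tested in a functional assay on L1210 cells (Mus musculus) for antiproliferative activity; a higher number here means a weaker inhibitor, a lower number a stronger inhibitor. Compound 1, `COc1cc(C(=O)c2sc(-c3ccc(C)cc3)cc2N)cc(OC)c1OC`, gives 18 nM, the second highest of the three numbers. Compound 2, `COc1cc(C(=O)c2sc(-c3ccc(F)cc3)cc2N)cc(OC)c1OC`, gives 20 nM, and compound 3, `COc1cc(C(=O)c2sc(-c3ccccc3)cc2N)cc(OC)c1OC`, gives 11 nM. The gaps are small: a 1.1-fold higher number from compound 1 to compound 2 (0.05 log units; within the scatter), a 1.6-fold lower number from compound 1 to compound 3 (0.21 log units; within the scatter) and a 1.8-fold lower number from compound 2 to compound 3 (0.26 log units; within the scatter) all stay within the scatter, and none of the three can be called stronger or weaker than the others.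

Compound 4, `COc1cccc(-c2cc(N)c(C(=O)c3cc(OC)c(OC)c(OC)c3)s2)c1`, differs from compound 1 in one place: 3-methoxyphenyl in place of 4-methylphenyl on an aromatic carbon. Among the compounds with values here, two measured steps bear on this change, both starting from compound 1 and both also replacing the methyl of the 4-methylphenyl; neither moved the number beyond the scatter. A methoxy has not been tried at this place before, and the size of its effect is therefore open. With every change made here lying within the scatter, no step beyond it is expected this time either; the expected step is a 1.1-fold lower number from compound 1 to compound 4 (0.05 log units; within the scatter). Compound 4 is estimated at 16 nM, with a range from 6 nM to 45 nM.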

Compound 4, half-maximal inhibitory concentration: 22 nM
For compound 4 the middle estimate is 1.4-fold (0.14 log units) below the measured one; the range from low to high includes it.
By their numbers in this assay, from the lowest: compounds 3, 1, 2 and 4 (each within the scatter of the next).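

Putting 3-methoxyphenyl in place of 4-methylphenyl gives a small step (a 1.2-fold higher number from compound 1 to compound 4 (0.09 log units; within the scatter)), so in this assay the number stays within the scatter even with an oxygen-bearing group attached at a different carbon of the phenyl ring. Compound 4 also stays within the scatter of the other two compounds (a 1.1-fold higher number from compound 2 to compound 4 (0.04 log units; within the scatter); a 2.0-fold higher number from compound 3 to compound 4 (0.30 log units; within the scatter)), which means that all four compounds remain indistinguishable in this assay. The data offer no explanation for why these changes have so little effect.

Compound 4 alters both the group and its place on the phenyl ring, so a 4-methoxyphenyl compound would be needed to separate the two changes. As far as these compounds go, it also remains open whether an amine or a carboxylic acid on this phenyl ring would move the number beyond the scatter.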